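The compounds below may be only part of what the source reports. "The series", "measured", "known", "first", "only" and "open" are said of these compounds alone.

For the measured compounds named here, in a functional assay on HCT-116 cells (Homo sapiens) for antiproliferative activity, read by MTT assay, with a stated time of 24 h (a higher number here means a weaker inhibitor, a lower number a stronger inhibitor), compound 1 (`COc1ccc(-c2noc(C3CCNCC3)n2)cc1OC1CCCC1`) gives 1540 nM as the only true number so far. Sharing the core of compound 1, compound 2 (`COc1ccc(-c2noc(Cc3c[nH]c4ccccc34)n2)cc1OC1CCCC1`) reports only a limit (> 1000000 nM). Compound 3 (`Fc1ccc(-c2nc(-c3ccccc3)no2)cc1`) also reports only a limit (> 1000000 nM).

Compound 4 (`COc1ccc(-c2noc(-c3ccc(Cl)cc3)n2)cc1OC1CCCC1`) carries 4-chlorophenyl in place of the piperidin-4-yl of compound 1, on an aromatic carbon of the five-membered aromatic ring with 2 nitrogen and 1 oxygen (4-chlorophenyl in place of piperidin-4-yl on an aromatic carbon). Going by the values given here, no step between measured compounds is available to size this change. Among the compounds with values here, a clear weakening in this assay beyond the scatter is nevertheless expected, resting on compound 2, compound 3 and the limit of > 1000000 nM in this assay, at which 2 of the 3 values shown sit, as the only guide. Among the three measured compounds, only compound 1 has piperidin-4-yl and only compound 1 gives a number. A limit reading for the new compound would fit this picture. The estimate gives a 19-fold higher number from compound 1 to compound 4 (1.29 log units; beyond the scatter) as the expected step. Compound 4 is expected at 30000 nM within an estimated range from 2000 nM to 500000 nM in this read-out.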

Compound 4, half-maximal inhibitory concentration: > 1000000 nM
Compound 4 was reported as a limit (the forecaster's own chance of this, stated with the estimate: 40%); middle value at least 33-fold (1.52 log units) away from the limit.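

Swapping piperidin-4-yl for 4-chlorophenyl on this aromatic carbon gives the first step that can be sized at this position: in this assay, the change produces an at least 640-fold higher number from compound 1 to compound 4 (2.81 log units; beyond the scatter), and the true size remains open. Compound 4 reports only a limit, > 1000000 nM. Compound 1 remains the only compound with piperidin-4-yl and the only one with a true number, while this new reading adds to the values at the assay limit: the limit of > 1000000 nM in this assay, at which 3 of the 4 values shown sit.

The compounds shown do not separate the contribution of the nitrogen of piperidin-4-yl from that of the saturated ring, a question that cyclohexyl at this carbon would address. As far as these compounds go, how much change piperidin-4-yl tolerates also remains open, including a methyl group on its nitrogen or an open-chain amine such as aminomethyl in its place.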